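Adding a Methyl to the Isopropyl of Compound 3

The compounds below may be only part of what the source reports. "The series", "measured", "known", "first", "only" and "open" are said of these compounds alone.

Compound 1 `COc1ccc(-c2cc3cc(C4C(C#N)=C(N)OC5=C4C(=O)CCC5)cc(C(C)C)c3oc2=O)cc1` gives 69.7% in a functional assay on the whole organism (strain Swiss albino) with Mus musculus as the target, in the forced swim test, with a stated time of 5 min, at a dose of 0.5 mg/kg by the intraperitoneal route; a lower number here means less inhibition, a higher number more inhibition at the dose given (going by the name of the read-out).
Compound 2 `COc1ccc(-c2cc3cc(C4C(C#N)=C(N)OC5=C4C(=O)CCC5)cc(C(C)C)c3oc2=O)cc1OC` gives 57.2%.
Compound 3 `COc1cc(-c2cc3cc(C4C(C#N)=C(N)OC5=C4C(=O)CCC5)cc(C(C)C)c3oc2=O)cc(OC)c1OC` gives 31.9%.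

Compound 3 stands lowest of the three numbers. Its nearest neighbour is compound 2, and the gap a number 25.3 percentage points lower from compound 2 to compound 3 (beyond the scatter) lies beyond the scatter, as does the larger gap a number 37.8 percentage points lower from compound 1 to compound 3 (beyond the scatter). The step of a number 12.5 percentage points lower from compound 1 to compound 2 (beyond the scatter) is of the same kind, a methoxy in place of hydrogen on an aromatic carbon, and also beyond the scatter. All three measured steps therefore concern methoxy groups on aromatic carbons.

Compound 4 `COc1cc(-c2cc3cc(C4C(C#N)=C(N)OC5=C4C(=O)CCC5)cc(C(C)(C)C)c3oc2=O)cc(OC)c1OC` differs from compound 3 in another place: methyl in place of hydrogen on a saturated chain carbon bound to an aromatic carbon and two saturated chain carbons. Read one bond further out, the same difference is isopropyl to tert-butyl. For the measured compounds named here, none of the measured steps touches this group, so the numbers at hand give no guide of their own to what the change will do. With nothing pointing either way, the expected step is a number 0.1 percentage points higher from compound 3 to compound 4 (within the scatter), that is, none beyond the scatter. Going by the values given here, the estimate for compound 4 is therefore 32%, with a range from 15% to 50% set wide to reflect that no measured step speaks to this change.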

Compound 4, a percentage reported as inhibition, in the whole organism at one dose (the size of the read-out at that dose, not a potency): 5.33%
Compound 4: the middle estimate sits 26.7 percentage points above what was measured, and the stated range ends above it.
By their numbers in this assay, from the lowest: compound 4; then compound 3; then compound 2; then compound 1.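

In this assay, the change from isopropyl to tert-butyl, a methyl in place of hydrogen on a saturated chain carbon bound to an aromatic carbon and two saturated chain carbons, gives a number 26.6 percentage points lower from compound 3 to compound 4 (beyond the scatter). This shows that the read-out responds to this group as well: every earlier step concerned methoxy groups on aromatic carbons, whereas here the 3,4,5-trimethoxyphenyl stays the same and a single added methyl is enough to move the number beyond the scatter. Nothing available on the compounds explains this fall, so the step stands as an observation only.

The compounds shown leave open whether a step of this kind would also appear with the 4-methoxyphenyl of compound 1, as this change is seen only on the 3,4,5-trimethoxyphenyl background of compound 3 and compound 4. They also leave open how the read-out would respond to other groups in place of the isopropyl, such as an ethyl, a cyclopropyl or a methoxy, so two groups at this place cannot yet be read as a trend.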